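The compounds below may be only part of what the source reports. "The series", "measured", "known", "first", "only" and "open" are said of these compounds alone.

Measured compounds in the series:

- compound 1, `O=C(Nc1cccc(NC(=S)Nc2ccccc2)c1)c1ccccn1`: 4400 nM
- compound 2, `O=C(CSC(=S)N1CCCCC1)Nc1cccc(NC(=O)c2ccccn2)c1`: 320 nM
- compound 3, `CCN1CCN(C(=S)SCC(=O)Nc2cccc(NC(=O)c3ccccn3)c2)CC1`: 3720 nM

In a functional assay on A549 cells (Homo sapiens) for antiproliferative activity, read by MTT assay, with a stated time of 48 h (a higher number here means a weaker inhibitor, a lower number a stronger inhibitor), compound 3 stands second highest of the three numbers, next to compound 1, which gives 4400 nM; the two lie within the scatter of each other, so no order between them is claimed. For the measured compounds named here, compound 2 sits far off, with 320 nM, and the only one-place step measured so far is a 12-fold higher number from compound 2 to compound 3 (1.07 log units; beyond the scatter), a large step.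

The next compound, compound 4, `O=C(CSC(=S)N1CCN(c2ccccc2)CC1)Nc1cccc(NC(=O)c2ccccn2)c1`, differs from compound 3 by phenyl in place of ethyl on an amine nitrogen in a ring. Going by the values given here, no measured step touches this nitrogen substituent; the one step that bears on the same region of the molecule, a 12-fold higher number from compound 2 to compound 3 (1.07 log units; beyond the scatter), exchanged the whole ring and says nothing about what a larger group on the ring nitrogen does. Among the compounds with values here, with only that indirect guide, compound 4 is expected to change by a 2.1-fold lower number from compound 3 to compound 4 (0.32 log units; beyond the scatter) in this assay, a step that could fall on either side of the scatter. The estimate for compound 4 in this assay is 1800 nM, within a range from 400 nM to 7000 nM.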

Compound 4, half-maximal inhibitory concentration: 530 nM
Beside the measured number, compound 4's estimate is 3.4-fold (0.53 log units) above it, and the stated range covers the measured number.
By their numbers in this assay, from the lowest: compounds 2 and 4 (each within the scatter of the next); then compounds 3 and 1 (each within the scatter of the next).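

In this assay the group on the amine nitrogen in the ring clearly counts: phenyl in place of ethyl gives a 7.0-fold lower number from compound 3 to compound 4 (0.85 log units; beyond the scatter) and shows that this nitrogen is a position where one substituent exchange alone moves the number beyond the scatter. The earlier ring exchange could not show this, and the printed values of compound 2 (320 nM) and compound 4 (530 nM) lie within the scatter of each other, so a ring with this second nitrogen does not by itself go with the higher number. No measured evidence at hand accounts for the step.

As far as these compounds go, it remains open whether the aromatic ring is what matters, since a cyclohexyl or a benzyl group on this nitrogen could separate ring type from ring placement. From the compounds shown here alone, how a phenyl ring carrying a methoxy group or a chlorine atom would read also remains open.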